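Adding bromo to compound 1: expected cytotoxicity step

The compounds below may be only part of what the source reports. "The series", "measured", "known", "first", "only" and "open" are said of these compounds alone.

In a functional assay on NALM-6 cells (Homo sapiens) for cytotoxicity, read by MTT assay, with a stated time of 46 h (a higher number here means a weaker inhibitor, a lower number a stronger inhibitor), compound 1 (`O=C1/C(=C/c2ccccc2)C(c2ccccc2)Oc2ccccc21`) gives 29500 nM, the higher of the two numeric values in the series. The nearest value belongs to compound 2 (`O=C1/C(=C/c2ccccc2)C(c2ccccc2)Oc2ccc(O)cc21`), which gives 8700 nM. Compound 3 (`O=C1/C(=C\c2ccc(Cl)cc2)C(c2ccccc2)Oc2ccccc21`) gives > 1000000 nM, and this is a limit of this assay, not a number.

The next structure is compound 4 (`O=C1/C(=C/c2ccc(Br)cc2)C(c2ccccc2)Oc2ccccc21`). It carries bromo in place of hydrogen on an aromatic carbon, with phenyl becoming 4-bromophenyl: bromo in place of hydrogen on an aromatic carbon. The new group sits on a six-membered aromatic ring of carbon only, para to a large group.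

Among the measured compounds shown here, only one measured step starts from compound 1, and it is modest: a 3.4-fold lower number from compound 1 to compound 2 (0.53 log units; beyond the scatter). That step brings in hydroxy rather than bromo, so it is a loose guide to size and says little about direction. Compound 3 provides no numeric comparison. For the measured compounds named here, a change beyond the scatter is therefore not expected in this assay, although the single step leaves wide uncertainty on both sides.

The expected change is a 1.5-fold lower number from compound 1 to compound 4 (0.17 log units; within the scatter). For compound 4 the estimated value is 20000 nM, with an expected range from 5000 nM to 80000 nM.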

Compound 4, half-maximal inhibitory concentration: 6900 nM
Compound 4: the middle estimate sits 2.9-fold (0.46 log units) above what was measured, within the range that was stated.
By their numbers in this assay, from the lowest: compounds 4 and 2 (each within the scatter of the next); then compound 1. At a limit, above all of these: compound 3.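

In this assay, the first read at this position, on an aromatic carbon para to a large group, is a 4.3-fold lower number from compound 1 to compound 4 (0.63 log units; beyond the scatter), so bromo here lowers the number rather than raising it. Compound 1 now has two single-place changes that lower the number, the other being a 3.4-fold lower number from compound 1 to compound 2 (0.53 log units; beyond the scatter), and both are printed as modest, though hydroxy sits elsewhere on the core and the two steps do not describe one position. Compound 3 gives > 1000000 nM, which is a limit and not a number, and it differs from compound 4 in more than one place, so no step can be read from it: the limit of > 1000000 nM in this assay, at which 1 of the 4 values shown sits.

Among the compounds shown here, with bromo as the only group with a numeric value at this position, the data cannot separate an effect of bromo itself from that of any substituent at this carbon, and an amine or a carboxylic acid on the same carbon would test this. Also open, on these data alone, are whether hydroxy and bromo together on the core of compound 1 would lower the number further, and what the double-bond geometry alone contributes.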